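This account rests on a few compounds, and the source may have more. Where it says the series, first, only, none or still open, it means among the compounds named here.

Measured compounds:

compound 1, `COc1ccc(-c2cc(/C=C/C(=O)c3ccc(N)cc3)[nH]n2)cc1`, 103%
compound 2, `COc1ccc(-c2cc(/C=C/C(=O)c3ccc(N)cc3)[nH]n2)cc1OC`, 102%
compound 3, `COc1cc(C(=O)/C=C/c2cc(-c3cc(OC)c(OC)c(OC)c3)n[nH]2)cc(OC)c1OC`, 95%

All three were run in a functional assay on SK-OV-3 cells (Homo sapiens) for cytotoxicity, read by sulforhodamine B assay, with a stated time of 48 h, tested at 0.1 uM; on this read-out higher numbers stand for a weaker effect at the one concentration tested and lower numbers for a stronger effect. Compound 1 gives 103%, compound 2 gives 102% and compound 3 gives 95%; the three numbers sit within the usual scatter of one another, so no order among them is claimed.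

Compound 2 and compound 1 differ in one place, (hydrogen in place of methoxy on an aromatic carbon), and this change made a step of a number 1 percentage points higher from compound 2 to compound 1 (within the scatter). The difference between the cores of compound 2 and compound 3 is not broken down here; their values show only that both sit in the same range in this assay.

Compound 4, `COc1ccc(-c2cc(/C=C/C(=O)c3cc(OC)c(OC)c(OC)c3)[nH]n2)cc1OC`, is not yet measured. It arises from compound 3 by hydrogen in place of methoxy on an aromatic carbon. This is the same kind of change as that from compound 2 to compound 1, and among the compounds shown it occurs two times in all, but the surroundings are not the same word for word: in compound 3 the carbon that loses the methoxy is also meta to a methoxy group, whereas in compound 2 it is only ortho to a methoxy group and meta to a large group.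

For compound 4 a step of a number 1 percentage points higher from compound 3 to compound 4 (within the scatter) is expected in this assay, resting on the step of a number 1 percentage points higher from compound 2 to compound 1 (within the scatter), which lay within the scatter. Compound 4 is therefore estimated at 96%, with a range from 85% to 106%.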

Compound 4, a percentage reported as activity, at one concentration (the size of the read-out at that concentration, not a potency): 87%
Compound 4: the middle estimate sits 9 percentage points above what was measured; measured number inside the range.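

In this assay, hydrogen in place of methoxy on an aromatic carbon now gives a number 8 percentage points lower from compound 3 to compound 4 (within the scatter), so the change has been read on two cores of the series. Set side by side, the two steps cannot be told apart, and on these two cores the change carries over as a step that stays within the scatter: the same change on two cores in this assay, a number 1 percentage points higher (within the scatter) from compound 2 to compound 1 and a number 8 percentage points lower (within the scatter) from compound 3 to compound 4, 9 percentage points apart, within the scatter of two such steps. Within the data shown here, this does not show that the change is without effect or that the result will hold on a third core, as it rests on only two pairs read at one concentration, and neither step is large enough to give a direction that could be carried from one core to the other.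

The compounds shown leave open whether any other replacement for the methoxy on this aromatic carbon, such as a hydroxy group, a chlorine atom, a carboxylic acid or a longer chain such as ethoxy, would move the read-out beyond the scatter. Also open, on these data alone, is whether the same pairs would remain indistinguishable at a concentration other than the single one tested here, where a difference between the two cores might or might not appear.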